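A few compounds are considered here, and "the series" means these few. Any claim that something is new, unique, unknown or untested is made for them only; others in the source may bear on it.

Measured so far in a functional assay on A2780 cells (Homo sapiens) for inhibition, read by sulforhodamine B assay; on this read-out lower numbers stand for stronger inhibition of growth and higher numbers for weaker inhibition of growth:
- compound 1 `COc1ccc(-c2ccc(-c3ccc(-c4nc5cc(C)ccc5[nH]4)cc3)cc2)cc1OC`: 2130 nM
- compound 2 `FC(F)(F)Oc1ccc(-c2ccc(-c3ccc(-c4nc5ccccc5[nH]4)cc3)cc2)cc1`: 100000 nM
- compound 3 `Cc1ccc2[nH]c(-c3ccc(-c4ccc(-c5ccc(C(F)(F)F)cc5)cc4)cc3)nc2c1`: 12300 nM

Compound 3 holds the middle place among these three numbers, higher than compound 1 and lower than compound 2. The next compound is compound 4 `Cc1ccc2[nH]c(-c3ccc(-c4ccc(-c5ccc(OC(F)(F)F)cc5)cc4)cc3)nc2c1`, with the change trifluoromethoxy in place of trifluoromethyl on an aromatic carbon, para to a large group.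

Among the compounds with values here, one measured step bears on this place: a 5.8-fold higher number from compound 1 to compound 3 (0.76 log units; beyond the scatter). It shows that a substituent swap here can move the number, but it swaps a different pair of groups. Within the data shown here, no measured step exchanges trifluoromethyl for trifluoromethoxy directly. Compound 2 also carries trifluoromethoxy and gives 100000 nM, but it differs from compound 4 elsewhere too, so it only tilts the expectation upward.

The estimated step is a 1.6-fold higher number from compound 3 to compound 4 (0.21 log units; within the scatter), towards a higher number and not clearly beyond the scatter. For compound 4 the expected value is 20000 nM, with an estimated range of 7000 nM to 70000 nM.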

Compound 4, concentration for 50% growth inhibition: 12300 nM
For compound 4 the middle estimate is 1.6-fold (0.21 log units) above the measured one, and the stated range covers the measured number.
By their numbers in this assay, from the lowest: compound 1; then compounds 3 and 4 (each within the scatter of the next); then compound 2.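

In this assay, trifluoromethoxy in place of trifluoromethyl on an aromatic carbon, para to a large group, gives no change at the digits printed from compound 3 to compound 4 (within the scatter), so this exchange does not separate the two compounds. With 4-(trifluoromethoxy)phenyl held constant, methyl in place of hydrogen on an aromatic carbon gives an 8.1-fold lower number from compound 2 to compound 4 (0.91 log units; beyond the scatter), which places the large gap to compound 2 on the methyl and not on the trifluoromethoxy group. Replacing 3,4-dimethoxyphenyl with 4-(trifluoromethoxy)phenyl gives a 5.8-fold higher number from compound 1 to compound 4 (0.76 log units; beyond the scatter), a step of the same printed size as a 5.8-fold higher number from compound 1 to compound 3 (0.76 log units; beyond the scatter), so both fluorinated groups stand on the same side of compound 1.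

As far as these compounds go, whether an amine or a carboxylic acid at this place would move the number in either direction remains open. Nothing available accounts for any of these steps.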